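The source may hold more compounds than are shown below. What is called first, only, known or untested is meant among the compounds shown, and "the series" means these compounds.

Measured so far: compound 1 `C[C@H](N)C(=O)NCc1cccnc1Oc1ccc(F)cc1F` with 14000 nM; compound 2 `CCC(c1ccc(OC)cc1)N(C)CCN` with > 25000 nM.

Going by the values given here, in an assay on isolated protein for inhibition of protein arginine N-methyltransferase 6 (Homo sapiens) (a higher number here means a weaker inhibitor, a lower number a stronger inhibitor), compound 1 gives 14000 nM, the only actual number among the two values shown. For compound 2 the entry > 25000 nM is a limit of this assay, not a number. Compound 3 `CC(C)(N)C(=O)NCc1cccnc1Oc1ccc(F)cc1F` differs from compound 1 by 1-amino-1-methylethyl in place of 1-aminoethyl on a carbonyl carbon. Among the compounds with values here, no step between measured compounds is available to calibrate this change, so only a small shift, within the usual scatter or slightly toward weaker inhibition, is expected. The step expected in this assay is a 1.3-fold higher number from compound 1 to compound 3 (0.11 log units; within the scatter). Compound 3 is therefore estimated at 18000 nM, in the range 6000 nM to 50000 nM.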

Compound 3, half-maximal inhibitory concentration: "not active" (no number reported)
Nothing numeric was reported for compound 3; the estimate stays without a comparison.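

Going by these compounds alone, compound 3 is reported only as not active, without a number, so no step from compound 1 to compound 3 can be read. It stays open whether 1-amino-1-methylethyl in place of 1-aminoethyl changes inhibition in this assay, and how that report relates to the one limit shown: the limit of > 25000 nM in this assay, at which 1 of the 3 values shown sits.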